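Working notes: methoxy to hydroxy in the series

The source may hold more compounds than are shown below. What is called first, only, known or untested is meant among the compounds shown, and "the series" means these compounds.

Measured so far:
- compound 1 `COc1cc2c(cc1C)NC(=O)/C2=C/c1c(OC)nc2sc(C)cn12`: 91700 nM
- compound 2 `COc1ccc2c(c1)/C(=C\c1c(OC)nc3sc(C)cn13)C(=O)N2`: 67700 nM

Going by the values given here, in a functional assay on cells (Melanoma cell) for cytotoxicity against Melanoma cell line (Homo sapiens), read by sulforhodamine B assay, with a stated time of 48 h (on this read-out lower numbers stand for stronger inhibition of growth and higher numbers for weaker inhibition of growth), compound 2 gives 67700 nM and lies within the scatter of compound 1, the only other measured compound, at 91700 nM. The next compound, compound 3 `COc1nc2sc(C)cn2c1/C=C1/C(=O)Nc2ccc(O)cc21`, carries hydrogen in place of methyl on an oxygen on an aromatic ring, that is, methoxy to hydroxy: hydrogen in place of methyl on an oxygen on an aromatic ring. Among the compounds with values here, one measured step bears on this, and only loosely: a 1.4-fold lower number from compound 1 to compound 2 (0.13 log units; within the scatter). It is also hydrogen in place of methyl, but on an aromatic carbon. No methoxy to hydroxy change has been measured in this series, so direct evidence is missing. No shift beyond the scatter is therefore expected in this assay, and neither direction is favoured. The expected change is a 1.1-fold lower number from compound 2 to compound 3 (0.05 log units; within the scatter). For compound 3 the estimated value is 60000 nM, with an expected range of 22000 nM to 120000 nM.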

Compound 3, concentration for total growth inhibition: 38600 nM
The estimate for compound 3 lay 1.6-fold (0.19 log units) above the measured number, and the stated range covers the measured number.
By their numbers in this assay, from the lowest: compounds 3, 2 and 1 (each within the scatter of the next, the first and the last beyond it).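

In this assay the methoxy to hydroxy change reads as a 1.8-fold lower number from compound 2 to compound 3 (0.24 log units; within the scatter). This gives a direct reading for hydrogen in place of methyl on an oxygen on an aromatic ring, where earlier there was only the loose parallel of the same swap on an aromatic carbon, a 1.4-fold lower number from compound 1 to compound 2 (0.13 log units; within the scatter). Both steps lie within the scatter, so neither the oxygen nor the carbon site shows a shift that can be told from repeat measurement, and no outside data bear on the new step.

From the compounds shown here alone, whether an amine or an ethoxy group at this place would give a shift beyond the scatter remains open. Also open, going by these compounds, is whether the other methoxy of the shared core responds to the same change in the same way.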